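Swapping cyclopropyl for bromomethyl on a carbonyl carbon

This account rests on a few compounds, and the source may have more. Where it says the series, first, only, none or still open, it means among the compounds named here.

Going by the values given here, in a functional assay on HCT-116 cells (Homo sapiens) for inhibition, read by MTT assay, with a stated time of 48 h (a lower number here means a stronger inhibitor, a higher number a weaker inhibitor), compound 2 `COc1ccc(CN(C(=O)C2CC2)c2cc(OC)c(OC)c(OC)c2)cc1O` gives 49 nM, the lower of the two numbers so far, while compound 1 `COCC(=O)N(Cc1ccc(OC)c(O)c1)c1cc(OC)c(OC)c(OC)c1` gives 230 nM. Compound 3 `COc1ccc(CN(C(=O)CBr)c2cc(OC)c(OC)c(OC)c2)cc1O` carries bromomethyl in place of cyclopropyl on a carbonyl carbon. Among the compounds with values here, only one measured step changes the group at this place: a 4.7-fold lower number from compound 1 to compound 2 (0.67 log units; beyond the scatter), which lies beyond the scatter. Within the data shown here, no measured compound carries bromomethyl, so the direction is uncertain, but a modest rise of no greater size is expected. The expected change is a 2.2-fold higher number from compound 2 to compound 3 (0.35 log units; beyond the scatter). The estimated value for compound 3 is 110 nM, within a range of 25 nM to 450 nM.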

Compound 3, half-maximal inhibitory concentration: 68 nM
Estimate against measurement, compound 3: 1.6-fold (0.21 log units) above; measured number inside the range.
By their numbers in this assay, from the lowest: compounds 2 and 3 (each within the scatter of the next); then compound 1.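

In this assay the swap of cyclopropyl for bromomethyl on a carbonyl carbon gives a 1.4-fold higher number from compound 2 to compound 3 (0.14 log units; within the scatter) and so, in these compounds, a ring at this place is not needed for a number of this size. On the saturated chain carbon bound to that carbonyl carbon, bromo in place of methoxy gives a 3.4-fold lower number from compound 1 to compound 3 (0.53 log units; beyond the scatter) and so the group carried there does change the number. No measurement here explains either step. Open, as far as these compounds go, is how a plain methyl, chloromethyl or a longer chain would compare at this place. Also open, from the compounds shown here alone, is whether a larger ring such as cyclobutyl would give a number like that of cyclopropyl.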